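Swapping a difluorophenyl amide for a bromophenyl sulfonamide

This account rests on a few compounds, and the source may have more. Where it says the series, first, only, none or still open, it means among the compounds named here.

Compound 3, `O=C(NCCNc1nccc(-c2c(-c3cccc(F)c3)nc3sccn23)n1)c1c(F)cccc1F`, gives 2700 nM in a functional assay on A-375 cells (Homo sapiens) for cytotoxicity, read by MTT assay (on this read-out higher numbers stand for weaker inhibition and lower numbers for stronger inhibition), the lowest of the three numbers recorded. Compound 2, `O=S(=O)(NCCNc1nccc(-c2c(-c3cccc(F)c3)nc3sccn23)n1)c1ccc(C(F)(F)F)cc1`, gives 7440 nM, and compound 1, `O=C(NCCCNc1nccc(-c2c(-c3cccc(F)c3)nc3sccn23)n1)c1ccc(Cl)cc1`, gives 13700 nM. Among the compounds with values here, the only single-point step among them, a 5.1-fold lower number from compound 1 to compound 3 (0.71 log units; beyond the scatter), changes both the aryl group and the chain length, so it does not isolate the change now in question.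

Compound 4, `O=S(=O)(NCCNc1nccc(-c2c(-c3cccc(F)c3)nc3sccn23)n1)c1ccc(Br)cc1`, differs from compound 3 in one place: (4-bromophenyl)sulfonyl in place of (2,6-difluorophenyl)carbonyl on an amine nitrogen. Compound 2 already carries a (4-trifluoromethylphenyl)sulfonyl group on the same nitrogen, so the values of compound 2 and compound 3 are the best guide: compound 2 sits above compound 3 by more than the scatter. Compound 4 is therefore expected to land near compound 2, with a step of a 2.4-fold higher number from compound 3 to compound 4 (0.38 log units; beyond the scatter) toward a higher number. The estimate for compound 4 in this assay is 6500 nM, within a range from 2500 nM to 17000 nM.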

Compound 4, half-maximal inhibitory concentration: 13500 nM
Beside the measured number, compound 4's estimate is 2.1-fold (0.32 log units) below it; measured number inside the range.
By their numbers in this assay, from the lowest: compound 3; then compounds 2, 4 and 1 (each within the scatter of the next).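

In this assay, putting (4-bromophenyl)sulfonyl in place of (2,6-difluorophenyl)carbonyl on this amine nitrogen gives a 5.0-fold higher number from compound 3 to compound 4 (0.70 log units; beyond the scatter), so this exchange weakens inhibition by more than the usual scatter. Among the sulfonyl compounds, bromo in place of trifluoromethyl on the aromatic ring gives a 1.8-fold higher number from compound 2 to compound 4 (0.26 log units; within the scatter), so that pair cannot be told apart here. The larger change that alters the chain as well as the group on it gives a 1.0-fold lower number from compound 1 to compound 4 (0.01 log units; within the scatter), which again shows no separation.

Nothing available here explains the weaker inhibition at this nitrogen. As far as these compounds go, whether it follows the sulfonyl link or the aryl group remains open, and a (4-bromophenyl)carbonyl or (2,6-difluorophenyl)sulfonyl group on the same nitrogen would separate the two.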